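A Ring Swap at a Saturated Carbon: Expected Stability

A few compounds are considered here, and "the series" means these few. Any claim that something is new, unique, unknown or untested is made for them only; others in the source may bear on it.

Measured so far:
Compound 1, `Cc1nc(N2CCC(N3CCOC3=O)CC2)nc2ccc(NC(=O)/C=C/c3ccc(OC(F)(F)F)cc3)cc12`: 85%
Compound 2, `COCC(=O)NC1CCN(c2nc(C)c3cc(NC(=O)/C=C/c4ccc(OC(F)(F)F)cc4)ccc3n2)CC1`: 58%

In an ADME assay on microsomes from liver (Homo sapiens) for metabolic stability, with a stated time of 30 min (on this read-out higher numbers stand for a more stable compound and lower numbers for a less stable compound), compound 1 gives 85%, the higher of the two numbers; compound 2 gives 58% in this assay. Within the data shown here, the only measured step, a number 27 percentage points lower from compound 1 to compound 2 (beyond the scatter), replaced the 2-oxo-1,3-oxazolidin-3-yl group on the saturated ring carbon with an open-chain ((methoxymethyl)carbonyl)amino group.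

Compound 3, `Cc1nc(N2CCC(N3CCCC3=O)CC2)nc2ccc(NC(=O)/C=C/c3ccc(OC(F)(F)F)cc3)cc12`, is not yet measured. It differs from compound 1 by 2-oxopyrrolidin-1-yl in place of 2-oxo-1,3-oxazolidin-3-yl on a saturated ring carbon. The step from compound 1 to compound 2 is the one that bears on this change, since it alters the same saturated ring carbon of the shared core; it was modest and beyond the scatter. The present change is smaller in kind: a five-membered ring stays in place and one hetero atom is exchanged for carbon. A step in this assay smaller than that from compound 1 to compound 2 is therefore expected, most likely within the scatter or a slight drop, a number 7 percentage points lower from compound 1 to compound 3 (within the scatter). Compound 3 is estimated at 78%, with a range from 62% to 92%.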

Compound 3, percent of the compound remaining: 76%
The estimate for compound 3 lay 2 percentage points above the measured number; the measured number falls inside the stated range.
By their numbers in this assay, from the lowest: compound 2; then compounds 3 and 1 (each within the scatter of the next).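

In this assay, exchanging one hetero atom of the 2-oxo-1,3-oxazolidin-3-yl group for carbon, which leaves the 2-oxopyrrolidin-1-yl group on the saturated ring carbon, gives a number 9 percentage points lower from compound 1 to compound 3 (within the scatter) and so does not separate the two five-membered rings on this read-out. Replacing the open-chain ((methoxymethyl)carbonyl)amino group with the 2-oxopyrrolidin-1-yl group gives a number 18 percentage points higher from compound 2 to compound 3 (beyond the scatter) and thus provides a second ring that stands apart from the open chain beyond the scatter, where previously there was only one. Among these three compounds, the two with a five-membered ring at this carbon therefore sit within the scatter of each other, while compound 2, the only open-chain example, is set apart from both, and no compound shown goes against this, although a single open chain is a narrow base for the pattern.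

Going by these compounds, it remains open whether this pattern would extend to an amine, a carboxylic acid or a longer chain at the same saturated ring carbon. Nothing available speaks to what lies behind these differences.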